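Methoxy for methyl, compound 2 to compound 3

The source may report more compounds than this note shows. Statements on the series, on what has been measured and on what is new or still open speak of the compounds shown alone.

Compound 1 `Oc1ccccc1CNc1ccc(N2CCNCC2)cc1`: in a functional assay on Jurkat cells (Homo sapiens) for activation, with a stated time of 24 h (on this read-out lower numbers stand for an effect already at smaller amounts and higher numbers for an effect only at larger amounts of compound), compound 1 gives "not active" (no number reported), with no number reported.
Compound 2 `Cc1ccc(-c2ccc(NCc3ccccc3O)cc2)cc1`: in this assay compound 2 gives 3790 nM.

Compound 2 thus holds the only number shown in the series; compound 1 offers no value to compare against. Compound 3 `COc1ccc(-c2ccc(NCc3ccccc3O)cc2)cc1` differs from compound 2 by methoxy in place of methyl on an aromatic carbon. Going by the values given here, no step between measured compounds exists to guide the size of this change, so in this assay a shift within the usual scatter is expected, with a slight lean toward larger amounts not ruled out. Compound 3 is estimated at 3500 nM, with a range from 1200 nM to 10000 nM. The expected step of a 1.1-fold lower number from compound 2 to compound 3 (0.03 log units; within the scatter) is accordingly small.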

Compound 3, half-maximal effective concentration: 580 nM
Compound 3: the middle estimate sits 6.0-fold (0.78 log units) above what was measured; measured number below the stated range.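

Going by these compounds alone, on the aromatic carbon para to a large group, methoxy in place of methyl gives in this assay a 6.5-fold lower number from compound 2 to compound 3 (0.82 log units; beyond the scatter) and so provides the first readable step, one beyond the scatter. This position therefore responds to a change of one heavy atom, which compound 1, without a number, could not show. Nothing measured here bears on the reason for this shift.

On these data alone, whether the gain is specific to methoxy remains open. Ethoxy, hydroxyl or an amine on the same carbon would test this, and none of these groups is among the compounds shown.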